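The source may report more compounds than this note shows. Statements on the series, on what has been measured and on what is new or still open speak of the compounds shown alone.

For the measured compounds named here, in a functional assay on MCF7 cells (Homo sapiens) for inhibition, read by sulforhodamine B assay (a higher number here means a weaker inhibitor of growth, a lower number a stronger inhibitor of growth), three compounds have numbers so far. Compound 1 (`COc1ccc(-c2ccc(-c3ccc(-c4nc5cc(C)ccc5[nH]4)cc3)cc2)cc1OC`) gives 190 nM, and compound 2 (`COc1cc(-c2ccc(-c3ccc(-c4nc5cc(C)ccc5[nH]4)cc3)cc2)cc(OC)c1OC`) gives 170 nM. Compound 3 (`FC(F)(F)c1ccc(-c2ccc(-c3ccc(-c4nc5ccccc5[nH]4)cc3)cc2)cc1`) gives 41400 nM, the highest number of the three, which makes it the weakest inhibitor of growth here, and its distance from both others lies beyond the scatter.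

Compound 4 (`CN(C)c1ccc(-c2ccc(-c3ccc(-c4nc5ccccc5[nH]4)cc3)cc2)cc1`) keeps the shared core of compound 3 and changes one group: dimethylamino in place of trifluoromethyl on an aromatic carbon, para to a large group (dimethylamino in place of trifluoromethyl on an aromatic carbon). Going by the values given here, no measured step tests this change directly. Among the compounds with values here, the only step available, a 1.1-fold lower number from compound 1 to compound 2 (0.05 log units; within the scatter), adds a methoxy, lies within the scatter and concerns a different group. Compounds 1 and 2 differ from compound 3 in more than one place, including a methyl on the core, so their gap from compound 3 cannot be tied to any single change. Even so, compound 1, which has no trifluoromethyl, stands at 190 nM, and this points to a lower number once that group is gone, though with wide uncertainty.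

The expected change, a 28-fold lower number from compound 3 to compound 4 (1.44 log units; beyond the scatter), is therefore a clear move toward stronger inhibition. For compound 4 the estimated value is 1500 nM, with an expected range from 200 nM to 20000 nM.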

Compound 4, concentration for 50% growth inhibition: 41200 nM
Beside the measured number, compound 4's estimate is 27-fold (1.44 log units) below it; measured number above the stated range.
By their numbers in this assay, from the lowest: compounds 2 and 1 (each within the scatter of the next); then compounds 4 and 3 (each within the scatter of the next).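

In this assay, the step of a 1.0-fold lower number from compound 3 to compound 4 (0.00 log units; within the scatter) lies within the scatter, so at this position, on an aromatic carbon para to a large group, trifluoromethyl and dimethylamino cannot be told apart, even though dimethylamino brings nitrogen and a hydrogen-bond acceptor while trifluoromethyl brings fluorine and no acceptor. For the compounds shown here, this is the first direct test of this position, and it shows that on this core, taking away trifluoromethyl is not enough on its own to give a stronger inhibitor of growth, at least when dimethylamino is what replaces it. Nothing measured here explains why these two different groups give matching numbers.

From the compounds shown here alone, compounds 1 and 2 differ from compounds 3 and 4 in more than one place, including the methyl on the core, so it remains open which of those differences separates the two pairs. Going by these compounds, it also remains open whether this position responds to any group at all, since a carboxylic acid, a primary amine or a longer chain here, or a methoxy on this core without the methyl, could still show whether the number can move.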